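The compounds below may be only part of what the source reports. "The series", "measured", "known", "first", "only" and "open" are said of these compounds alone.

Measured compounds:

compound 1, `CSc1nnc(-c2ccc(C)cc2)n1C` — in a functional assay on the whole organism for antagonist activity, with Mus musculus as the target (a lower number here means that less compound is needed, a higher number that more compound is needed for the effect), compound 1 gives > 100 mg/kg, which is a limit of the assay rather than a number.
compound 2, `Cc1ccc(-c2nnc([S+](C)[O-])n2C)cc1` — in this assay compound 2 gives > 200 mg/kg, again a limit rather than a number.
compound 3, `CSc1nnc(-c2ccccc2F)n1C` — in this assay compound 3 gives 61.3 mg/kg, the only number among the three.

Compound 1 and compound 2 differ in one place: a group of 3 heavy atoms (1 carbon, 1 oxygen, 1 sulfur; no ring) in place of a group of 2 heavy atoms (1 carbon, 1 sulfur; no ring), on an aromatic carbon. The step between them in this assay is a step that the two limits leave unreadable from compound 1 to compound 2, since both values are limits; the two relevant lines are the limit of > 100 mg/kg in this assay, at which 1 of the 3 values shown sits, and (the limit of > 200 mg/kg in this assay, at which 1 of the 3 values shown sits), and neither fixes where the true values lie, so the size of this step cannot be read.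

Compound 3 carries a different core from compound 1, and the difference between the two cores is not broken down here.

Compound 4, `Cn1c(-c2ccccc2F)nnc1[S+](C)[O-]`, has not been measured in this assay. It stands to compound 3 as compound 2 stands to compound 1: a group of 3 heavy atoms (1 carbon, 1 oxygen, 1 sulfur; no ring) in place of a group of 2 heavy atoms (1 carbon, 1 sulfur; no ring), on an aromatic carbon. The place of the change is the same in words as for the pair of compound 1 and compound 2, so this is the same change.

Going by the values given here, the earlier step gives no readable size, so the expectation for compound 4 rests on compound 3 alone, whose value of 61.3 mg/kg is the only number available. A step of a 2.4-fold higher number from compound 3 to compound 4 (0.39 log units; beyond the scatter) is expected, with a wide range and a fair chance that only a limit is reported. Compound 4 is estimated to give 150 mg/kg in this assay, between 50 mg/kg and 500 mg/kg.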

Compound 4, dose for half-maximal effect: 57.9 mg/kg
Estimate against measurement, compound 4: 2.6-fold (0.41 log units) above; measured number inside the range.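

On the core of compound 3, putting the oxygen-bearing sulfur group in place of methylsulfanyl on the aromatic carbon gives a 1.1-fold lower number from compound 3 to compound 4 (0.02 log units; within the scatter) in this assay and so, on this core, the two compounds cannot be told apart. Going by these compounds alone, this does not show that the change behaves the same way on every core: compound 1 and compound 2 are both limits of the assay and not numbers, so the step between them cannot be read, and the one readable step comes from a single core. The measurements shown also give no explanation of why compound 3 and compound 4 cannot be told apart.

Going by these compounds, it remains open whether another group on the same aromatic carbon, such as an amine, a carboxylic acid, a sulfonyl group or a longer chain like ethylsulfanyl, would stay level with methylsulfanyl or move the dose needed. On these data alone, it is also open how the core of compound 1 and the core of compound 3 compare, since the difference between them is not broken down here, and a further core carrying both groups would be needed to show whether this result carries over.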